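Swapping 4-nitrophenyl for 2-hydroxyphenyl

The compounds below may be only part of what the source reports. "The series", "measured", "known", "first", "only" and "open" are said of these compounds alone.

In a functional assay on B16-F10 cells (Mus musculus) for antiproliferative activity, read by MTT assay, with a stated time of 48 h (on this read-out higher numbers stand for weaker inhibition and lower numbers for stronger inhibition), compound 1 `CC(=O)N1N=C(c2ccc3ccccc3c2)OC1c1ccccc1` gives 2.57 ug/mL, while compound 2 `CC(=O)N1N=C(c2ccc3ccccc3c2)OC1c1ccc([N+](=O)[O-])cc1` gives 9.32 ug/mL, the higher of the two numbers and so the weaker inhibition. Compound 3 `CC(=O)N1N=C(c2ccc3ccccc3c2)OC1c1ccccc1O` has not yet been measured. It differs from compound 2 as follows: 2-hydroxyphenyl in place of 4-nitrophenyl on a saturated ring carbon. In words, 2-hydroxyphenyl stands in place of 4-nitrophenyl on a saturated ring carbon. Within the data shown here, one measured step bears on this change: placing nitro in place of hydrogen on an aromatic carbon gave a 3.6-fold higher number from compound 1 to compound 2 (0.56 log units; beyond the scatter), a modest weakening. Compound 3 has no nitro group, so its number is expected to move back toward compound 1 at 2.57 ug/mL. Among the measured compounds shown here, no measured compound shows what the hydroxy group does, so the range stays wide. In this assay the expected change is a 2.7-fold lower number from compound 2 to compound 3 (0.43 log units; beyond the scatter), a modest move toward stronger inhibition. The estimated value for compound 3 is 3.5 ug/mL, with an expected range of 1 ug/mL to 11 ug/mL.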

Compound 3, half-maximal inhibitory concentration: 2.58 ug/mL
Compound 3: the middle estimate sits 1.4-fold (0.13 log units) above what was measured; the range from low to high includes it.
By their numbers in this assay, from the lowest: compounds 1 and 3 (each within the scatter of the next); then compound 2.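

Swapping the group on this saturated ring carbon gives a 3.6-fold lower number from compound 2 to compound 3 (0.56 log units; beyond the scatter) in this assay and shows that the weaker inhibition of compound 2 does not come with every substituted phenyl ring at this position. Placing hydroxy in place of hydrogen on the same phenyl ring gives a 1.0-fold higher number from compound 1 to compound 3 (0.00 log units; within the scatter) and so leaves compound 3 indistinguishable from compound 1, which means that here one added group weakens inhibition while another produces no detectable change. Nothing measured here explains why the nitro and hydroxy groups differ in this way.

On these data alone, whether the tolerance seen for hydroxy extends to other groups, such as a methoxy group, an amine or a carboxylic acid, remains open. With only one hydroxy compound and one nitro compound shown, no general rule for this phenyl ring can yet be drawn.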